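Swapping an aromatic group on a long-lasting compound

A few compounds are considered here, and "the series" means these few. Any claim that something is new, unique, unknown or untested is made for them only; others in the source may bear on it.

Compound 1 `CCCCCNC(=O)n1cc(-c2ccccc2)oc1=O`, compound 2 `CCOCCNC(=O)n1cc(-c2ccccc2)oc1=O` and compound 3 `COc1cccc(-c2cn(C(=O)NCCCCc3ccccc3)c(=O)o2)c1` share one core and differ in the groups attached to it. All three have been measured in an ADME assay on a cell-free system (plasma, Mus musculus) for metabolic stability, read by LC-MS, tested at 2 uM; a lower number here means that the compound disappears faster, a higher number that the compound lasts longer. In this assay compound 3 gives > 2 h, which is a limit and not a number. Compound 1 gives > 2 h, which is also a limit. Compound 2 gives an actual number, 1.33 h. Compound 3 therefore stands with much of this small set at one shared boundary, (the limit of > 2 h in this assay, at which 2 of the 3 values shown sit).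

Compound 4 `O=C(NCCCCc1ccccc1)n1cc(-c2cccnc2)oc1=O` keeps the rest of compound 3 but carries pyridin-3-yl in place of 3-methoxyphenyl on an aromatic carbon. For the measured compounds named here, no measured step covers this swap directly. Going by the values given here, the one measured step, an at least 1.5-fold lower number from compound 1 to compound 2 (0.17 log units; that floor lies within the scatter), concerns a saturated chain rather than an aromatic group, so it bears on this swap only loosely. It gives no reason to expect a large move, so no change beyond the scatter is expected in this assay, and no direction can be claimed with confidence. The estimated change is an at least 1.1-fold lower number from compound 3 to compound 4 (0.07 log units; that floor lies within the scatter). For compound 4 the expected half-life is 1.7 h, with an estimated range from 0.8 h to 3.2 h.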

Compound 4, half-life: 1 h
Estimate against measurement, compound 4: 1.7-fold (0.23 log units) above, within the range that was stated.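

In this assay, replacing 3-methoxyphenyl with pyridin-3-yl gives the first step seen at this position on the shared core: an at least 2.0-fold lower number from compound 3 to compound 4 (0.30 log units; that floor lies within the scatter). This step is only a floor, so the real gap could be larger, but the floor itself does not pass the usual scatter, and a drop cannot be claimed from it. Compound 3 has a limit and not a number, while compound 4 has a measured value and so stands off the boundary that compound 3 shares with compound 1: the limit of > 2 h in this assay, at which 2 of the 4 values shown sit.

The swap changes two things at once, since a methoxy group leaves and a ring nitrogen enters, and the compounds shown cannot separate these two changes. As far as these compounds go, it also remains open how the half-life would respond at this position to pyridin-4-yl, or to a phenyl ring carrying an amine or a carboxylic acid, and whether a measured number would appear there too.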